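Swapping isopropyl for thiophenylmethyl on a shared amine

The source may hold more compounds than are shown below. What is called first, only, known or untested is meant among the compounds shown, and "the series" means these compounds.

Compound 1 `COc1ccc(-c2cnc3nc(N)nc(NC(C)C)c3n2)cc1OC` gives 600 nM in a functional assay on cells (T-cell, Homo sapiens) for inhibition; on this read-out lower numbers stand for stronger inhibition and higher numbers for weaker inhibition.
Compound 2 `COc1ccc(-c2cnc3nc(N)nc(N4CCN(c5ccc(C)cc5)CC4)c3n2)cc1OC` gives 300 nM in this assay.

These two numbers lie within the usual scatter of each other, so neither compound 1 nor compound 2 can be called the stronger inhibitor. Compound 3 `COc1ccc(-c2cnc3nc(N)nc(NCc4cccs4)c3n2)cc1OC` has not yet been measured. It differs from compound 1 in one place: (thiophen-2-yl)methyl in place of isopropyl on a nitrogen on an aromatic ring. For the measured compounds named here, no step between measured compounds is available to show what this change does in this assay, so the expectation rests on compound 1 alone. A small step toward a lower number is expected, a 1.5-fold lower number from compound 1 to compound 3 (0.18 log units; within the scatter), probably not beyond the scatter. Compound 3 is therefore estimated at 400 nM, within a range of 100 nM to 1500 nM.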

Compound 3, half-maximal inhibitory concentration: 4100 nM
For compound 3 the middle estimate is 10-fold (1.01 log units) below the measured one; measured number outside the range, above it.
By their numbers in this assay, from the lowest: compounds 2 and 1 (each within the scatter of the next); then compound 3.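

In this assay, (thiophen-2-yl)methyl in place of isopropyl on this nitrogen brings a 6.8-fold higher number from compound 1 to compound 3 (0.83 log units; beyond the scatter), a clear move toward weaker inhibition. For the compounds shown here, compounds 1 and 2 lie within the scatter of each other, so only this step shows that the group on this nitrogen can change the result. Nothing shown here explains the rise.

On these data alone, whether benzyl, with a six-membered ring in place of the thiophene, would give a similar rise remains open. So does how a small chain such as ethyl would behave here.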